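Adding a 3-fluorophenyl on the amino-side chain carbon

This account rests on a few compounds, and the source may have more. Where it says the series, first, only, none or still open, it means among the compounds named here.

For the measured compounds named here, compound 2 `CCCCC#Cc1nc(NC)c2ncn([C@H]3[C@H](O)[C@H](O)[C@@H]4C[C@@H]43)c2n1` stands lowest of the two numbers measured so far in an assay on CHO cells for displacement of a labelled ligand from adenosine receptor A1 (Homo sapiens), read by scintillation counting, with a stated time of 60 min, tested at 10 uM (on this read-out lower numbers stand for less inhibition and higher numbers for more inhibition at the one concentration tested (going by the name of the read-out)), giving 14%. Compound 1 `CCCCC#Cc1nc(NCC)c2ncn([C@H]3[C@H](O)[C@H](O)[C@@H]4C[C@@H]43)c2n1` gives 31% in this assay. Going by the values given here, the single measured step, a number 17 percentage points lower from compound 1 to compound 2 (beyond the scatter), is hydrogen in place of methyl on a saturated chain carbon bound to a nitrogen on an aromatic ring, and it lies beyond the scatter. Compound 3 `CCCCC#Cc1nc(NCc2cccc(F)c2)c2ncn([C@H]3[C@H](O)[C@H](O)[C@@H]4C[C@@H]43)c2n1` has not been measured; it differs from compound 2 by 3-fluorophenyl in place of hydrogen on a saturated chain carbon bound to a nitrogen on an aromatic ring. The change therefore re-occupies the same carbon that lost its methyl in that step, now with a larger group. Among the compounds with values here, the one step that bears on it, a number 17 percentage points lower from compound 1 to compound 2 (beyond the scatter), points to an upward move when this carbon carries a substituent; how much further a 3-fluorophenyl goes is not fixed by anything measured here. Compound 3 is expected to give 38% (range 15% to 65%) in this assay, an estimated step of a number 24 percentage points higher from compound 2 to compound 3 (beyond the scatter).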

Compound 3, a percentage reported as inhibition, at one concentration (the size of the read-out at that concentration, not a potency): 21%
Compound 3: middle estimate off by 17 percentage points, on the high side; low and high end bracket the measured number.
By their numbers in this assay, from the lowest: compounds 2, 3 and 1 (each within the scatter of the next, the first and the last beyond it).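

In this assay the 3-fluorophenyl on the saturated chain carbon bound to a nitrogen on an aromatic ring leaves the read-out within the scatter of both smaller forms, with a number 7 percentage points higher from compound 2 to compound 3 (within the scatter) against hydrogen and a number 10 percentage points lower from compound 1 to compound 3 (within the scatter) against methyl in that place. The position thus accepts a group of this size without a change beyond the scatter, and the rise seen on going from hydrogen to methyl does not carry on in step with the size of the group. Nothing available gives a reason for this result.

As far as these compounds go, whether a longer chain such as propyl would take the read-out past that of compound 1 remains open. So does the part played by the fluorine, which a plain phenyl or a phenyl bearing an amine on the same carbon would test.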